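Toward the Methyl Ester of Compound 4

The source may report more compounds than this note shows. Statements on the series, on what has been measured and on what is new or still open speak of the compounds shown alone.

Measured in an ADME assay on HepG2 2.2.15 cells (Homo sapiens) for cytotoxicity; on this read-out lower numbers stand for higher toxicity in this test and higher numbers for lower toxicity in this test:
Compound 1 `N#CCC(=O)OCCc1c(-c2ccccc2Cl)c2cc(Cl)ccc2[nH]c1=O`: 100000 nM
Compound 2 `O=C(OCCc1c(-c2ccccc2Cl)c2cc(Cl)ccc2[nH]c1=O)c1ccc([N+](=O)[O-])cc1`: 1600000 nM
Compound 3 `O=C(/C=C/c1cccc(C(F)(F)F)c1)OCCc1c(-c2ccccc2Cl)c2cc(Cl)ccc2[nH]c1=O`: > 1400000 nM, a limit

Compound 3 has no exact number in this assay, only the limit > 1400000 nM. Compound 4 `C/C=C/C(=O)OCCc1c(-c2ccccc2Cl)c2cc(Cl)ccc2[nH]c1=O`, not yet measured, differs from it by methyl in place of 3-(trifluoromethyl)phenyl on a double-bonded chain carbon bound to a double-bonded chain carbon.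

The nearest evidence comes from changes to the group on the carbonyl carbon. Two steps away from the ringless cyanomethyl group were large: a 16-fold higher number from compound 1 to compound 2 (1.20 log units; beyond the scatter) and an at least 14-fold higher number from compound 1 to compound 3 (1.14 log units; beyond the scatter). The comparison between the two ring-bearing groups gives a step that the limit leaves unreadable from compound 2 to compound 3. Compound 4 also has no ring in this group, so it is expected to fall toward compound 1 at 100000 nM, though not necessarily all the way.

The expected change is an at least 3.5-fold lower number from compound 3 to compound 4 (0.54 log units; beyond the scatter), toward a lower number. For compound 4 the estimated value is 400000 nM, with an expected range of 100000 nM to 1500000 nM.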

Compound 4, half-maximal cytotoxic concentration: 30000 nM
For compound 4 the middle estimate is 13-fold (1.12 log units) above the measured one; measured number outside the range, below it.
By their numbers in this assay, from the lowest: compound 4; then compound 1; then compound 2.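

In this assay, losing the ring from this group goes with a large drop: methyl in place of 3-(trifluoromethyl)phenyl gives an at least 46-fold lower number from compound 3 to compound 4 (1.66 log units; beyond the scatter), and prop-1-en-1-yl in place of 4-nitrophenyl on a carbonyl carbon gives a 53-fold lower number from compound 2 to compound 4 (1.73 log units; beyond the scatter). The two ringless groups do not share one number either, as prop-1-en-1-yl in place of cyanomethyl gives a 3.3-fold lower number from compound 1 to compound 4 (0.52 log units; beyond the scatter), so among these four compounds the lowest number belongs to the group with the double bond and no ring. Compound 3 has only a limit, which makes its step to compound 4 a minimum and leaves the step between compound 2 and compound 3 unreadable: the limit of > 1400000 nM in this assay, at which 1 of the 4 values shown sits.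

Still open, from the compounds shown here alone, is whether any ring in this group raises the number or only these two substituted ones do. A plain phenyl, an amine or a longer saturated chain in the same place could separate those readings.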